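Adding a Methyl to the Aromatic Ring of Compound 2

The source may hold more compounds than are shown below. What is called first, only, known or untested is meant among the compounds shown, and "the series" means these compounds.

Measured so far:
compound 1 `CC1=CC[C@@H]([C@@](C)(O)CCCC(C)(C)NC(=S)NN)CC1`: 380 nM
compound 2 `CC1=CC[C@@H]([C@@](C)(O)CCCC(C)(C)NC(=S)N/N=C\c2ccccc2)CC1`: 20900 nM

Of the compounds shown here, two have been tested in a functional assay on K562 cells (Homo sapiens) for cytotoxicity, read by sulforhodamine B assay; a higher number here means a weaker inhibitor of growth, a lower number a stronger inhibitor of growth. Compound 1 gives 380 nM and compound 2 gives 20900 nM. Compound 2 thus stands at the highest of the two numbers, that is, it is the weaker growth inhibitor. Within the data shown here, the only measured step, a 55-fold higher number from compound 1 to compound 2 (1.74 log units; beyond the scatter), is large and well beyond the scatter, but it concerns a very different and much bigger exchange than the one considered next.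

Compound 3 `CC1=CC[C@@H]([C@@](C)(O)CCCC(C)(C)NC(=S)N/N=C\c2ccc(C)cc2)CC1` differs from compound 2 by methyl in place of hydrogen on an aromatic carbon. Among the measured compounds shown here, no measured step bears on such a small change; the data simply hold no example of a substituent on that aromatic ring. With nothing pointing either way, no step beyond the scatter is expected in this assay. Compound 3 is therefore estimated at 20000 nM, with a range from 8000 nM to 50000 nM. The expected step of a 1.0-fold lower number from compound 2 to compound 3 (0.02 log units; within the scatter) stays within the scatter.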

Compound 3, concentration for total growth inhibition: 7950 nM
Beside the measured number, compound 3's estimate is 2.5-fold (0.40 log units) above it, outside the stated range (below it).
By their numbers in this assay, from the lowest: compound 1; then compound 3; then compound 2.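

Among these compounds, this is the first substituent seen on the aromatic ring: in this assay, going from phenyl to 4-methylphenyl gives a 2.6-fold lower number from compound 2 to compound 3 (0.42 log units; beyond the scatter) and so a modestly stronger growth inhibitor, showing that even a single methyl on this ring carbon can shift the result. The methyl recovers only part of the loss linked to the larger group, as a 21-fold higher number from compound 1 to compound 3 (1.32 log units; beyond the scatter) still leaves a large gap on the weaker side of compound 1. Nothing available here explains why the methyl has this effect.

On these data alone, it remains open whether a methoxy group, a chlorine atom or a longer chain at this place would lower the number further or raise it again. As far as these compounds go, it is equally open whether any group on this ring could bring the number close to that of compound 1 at 380 nM in this assay.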